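The compounds below may be only part of what the source reports. "The series", "measured", "known", "first", "only" and "open" are said of these compounds alone.

Measured so far in a functional assay on ileum for inhibition of histamine H1 receptor (Cavia porcellus); on this read-out lower numbers stand for stronger inhibition and higher numbers for weaker inhibition:
compound 1 `CCCCCN1CCN(c2nc3ccccc3n2CCOCC)CC1`: 30 nM
compound 2 `CCCOCCn1c(N2CCN(C)CC2)nc2ccccc21`: 20 nM
compound 3 `CCCCCN1CCCN(c2nc3ccccc3n2CCOCC)CC1`: 7.4 nM

Compound 2 holds the second highest of the three numbers. Compound 1 is nearest to it, within the scatter, so these two cannot be placed in order; compound 3 is furthest from it, beyond the scatter, with the lower number. Compound 4 `CCCCCCCn1c(N2CCN(C)CC2)nc2ccccc21` has not yet been measured. Its difference from compound 2: pentyl in place of propoxy on a saturated chain carbon, two bonds along the chain from an aromatic nitrogen. Among the compounds with values here, no measured pair shows this change, so nothing here tells its direction; in this assay a small step is expected, probably none beyond the scatter. The expected step is no change at the digits printed from compound 2 to compound 4 (within the scatter). Compound 4 is estimated at 20 nM, with a range from 6 nM to 60 nM.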

Compound 4, half-maximal inhibitory concentration: 150 nM
The estimate for compound 4 lay 7.5-fold (0.88 log units) below the measured number; measured number above the stated range.
By their numbers in this assay, from the lowest: compound 3; then compounds 2 and 1 (each within the scatter of the next); then compound 4.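

Within the data shown here, this chain position is not indifferent to the change in this assay: pentyl in place of propoxy, on a saturated chain carbon, two bonds along the chain from an aromatic nitrogen, gives a 7.5-fold higher number from compound 2 to compound 4 (0.88 log units; beyond the scatter), the first single-place comparison. The swap replaces a group with one hydrogen-bond acceptor by an all-carbon group with none, but this single pair cannot separate that difference from the change in chain length.

On these data alone, how butoxy or a terminal amine would read at this place remains open. Nothing at hand accounts for the size of this step.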